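Removing one methyl from an oxygen: a cytotoxicity forecast

The source may report more compounds than this note shows. Statements on the series, on what has been measured and on what is new or still open speak of the compounds shown alone.

Three compounds sharing one core were tested in a functional assay on SK-MEL-5 cells (Homo sapiens) for cytotoxicity, read by sulforhodamine B assay, with a stated time of 48 h, tested at 0.01 uM; a lower number here means a stronger effect, a higher number a weaker effect of the compound at the concentration tested. Compound 1 `COc1cc(C)cc(-c2c(-c3ccnc(-c4ccc(C(C)=O)cc4)c3)cnn2CC#N)c1` gives 94%. Compound 2 `Cc1cc(O)cc(-c2nn(CC#N)cc2-c2ccnc(-c3ccc(Oc4ccccc4)cc3)c2)c1` gives 93%. Compound 3 `COc1cc(C)cc(-c2nn(CC#N)cc2-c2ccnc(-c3ccc(N(C)C)cc3)c2)c1` gives 104%, the highest of the three numbers, within the scatter of compound 1 and just beyond it relative to compound 2. All three numbers sit close to full cell growth, so at this concentration none of them shows a strong effect. Compound 4 `Cc1cc(O)cc(-c2nn(CC#N)cc2-c2ccnc(-c3ccc(N(C)C)cc3)c2)c1` has not yet been measured. It differs from compound 3 in one place: hydrogen in place of methyl on an oxygen on an aromatic ring. Among the measured compounds shown here, no measured pair offers a guide for this change. Because compound 3 gives 104% and the whole set sits near one level, the step of a number 6 percentage points lower from compound 3 to compound 4 (within the scatter) is expected to be none beyond the scatter. Compound 4 is estimated at 98%, expected between 86% and 110%.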

Compound 4, a percentage reported as activity, at one concentration (the size of the read-out at that concentration, not a potency): 90%
The estimate for compound 4 lay 8 percentage points above the measured number; measured number inside the range.
By their numbers in this assay, from the lowest: compounds 4, 2, 1 and 3 (each within the scatter of the next, the first and the last beyond it).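

In this assay, among the compounds shown here, going from methoxy to hydroxy gives a number 14 percentage points lower from compound 3 to compound 4 (beyond the scatter), the first measured step for this change at this oxygen. With hydroxy in place, dimethylamino in place of phenoxy on an aromatic carbon gives a number 3 percentage points lower from compound 2 to compound 4 (within the scatter), so these two compounds cannot be told apart. No measurement here explains the methoxy to hydroxy step. As far as these compounds go, what an ethyl group on that oxygen, or an amine in place of the hydroxy, would do remains open. From the compounds shown here alone, whether the step holds at higher concentrations is also open.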